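The source may report more compounds than this note shows. Statements on the series, on what has been measured and on what is new or still open speak of the compounds shown alone.

Compound 1, `C=CCOc1ccc(Br)cc1C(=O)c1cccnc1`, gives 78000 nM in a functional assay on Hep cells (Homo sapiens) for cytotoxicity, read by sulforhodamine B assay, with a stated time of 48 h; a lower number here means a stronger inhibitor, a higher number a weaker inhibitor.
Compound 2, `C=CCOc1ccc(C)cc1C(=O)c1cccnc1`, gives 72000 nM in this assay.
Compound 3, `Cc1ccc(O)c(C(=O)c2cccnc2)c1`, gives 11000 nM in this assay.

The change bromo in place of methyl on an aromatic carbon produced a 1.1-fold higher number from compound 2 to compound 1 (0.03 log units; within the scatter). The cores of compound 2 and compound 3 differ by hydrogen in place of allyl on an oxygen on an aromatic ring, and that difference produced a 6.5-fold lower number from compound 2 to compound 3 (0.82 log units; beyond the scatter). Compound 4, `O=C(c1cccnc1)c1cc(Br)ccc1O`, carries the change (bromo in place of methyl on an aromatic carbon); this is the same kind of change as that from compound 2 to compound 1, but here the place is para to a hydroxy group (1 heavy atom) rather than para to an allyloxy group (4 heavy atoms). A small step is expected, a 1.1-fold higher number from compound 3 to compound 4 (0.04 log units; within the scatter), because the same kind of change gave a 1.1-fold higher number from compound 2 to compound 1 (0.03 log units; within the scatter). Compound 4 is therefore estimated at 12000 nM in this assay, between 6000 nM and 25000 nM.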

Compound 4, half-maximal inhibitory concentration: 29000 nM
Beside the measured number, compound 4's estimate is 2.4-fold (0.38 log units) below it; measured number above the stated range.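

In this assay, bromo in place of methyl on an aromatic carbon gave a 2.6-fold higher number from compound 3 to compound 4 (0.42 log units; beyond the scatter), and this does not differ firmly from the same change on the allyl-bearing core: the same change on two cores in this assay, a 1.1-fold higher number (0.03 log units; within the scatter) from compound 2 to compound 1 and a 2.6-fold higher number (0.42 log units; beyond the scatter) from compound 3 to compound 4, 2.4-fold (0.39 log units) apart, within the scatter of two such steps. Hydrogen in place of allyl on an oxygen on an aromatic ring gave a 2.7-fold lower number from compound 1 to compound 4 (0.43 log units; beyond the scatter), again in the same direction as before and not firmly different from the earlier step: the same change on two cores in this assay, a 6.5-fold lower number (0.82 log units; beyond the scatter) from compound 2 to compound 3 and a 2.7-fold lower number (0.43 log units; beyond the scatter) from compound 1 to compound 4, 2.4-fold (0.39 log units) apart, within the scatter of two such steps. So both changes carry from one core to the other within the scatter, but two pairs do not show that the step sizes are equal, and the bromo change lies within the scatter on one core and beyond it on the other.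

The compounds shown leave open how a chloro or methoxy group would read in place of bromo. They also leave open how an amine or a longer chain would read on the oxygen in place of allyl.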